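Shortening the Hydroxamate Chain of Compound 1

The source may hold more compounds than are shown below. What is called first, only, known or untested is meant among the compounds shown, and "the series" means these compounds.

Compound 1 `CCOc1cc(C(C)(C)C)ccc1C1=NC(c2ccc(Cl)cc2)C(c2ccc(Cl)cc2)N1C(=O)N1CCN(CCCCCC(=O)NO)CC1` gives 4030 nM
Compound 2 `CCOc1cc(C(C)(C)C)ccc1C1=NC(c2ccc(Cl)cc2)C(c2ccc(Cl)cc2)N1C(=O)NCCCCCCCC(=O)NO` gives 5030 nM
Compound 3 `CCOc1cc(C(C)(C)C)ccc1C1=NC(c2ccc(Cl)cc2)C(c2ccc(Cl)cc2)N1C(=O)NCCCCCCC(=O)Nc1ccccc1N` gives 10100 nM

In a functional assay on HCT-116 cells (Homo sapiens) for antiproliferative activity, read by CCK-8 assay, with a stated time of 72 h (a lower number here means a stronger inhibitor, a higher number a weaker inhibitor), compound 1 stands at 4030 nM within the scatter of compound 2 and with a lower number than compound 3. Compound 4 `CCOc1cc(C(C)(C)C)ccc1C1=NC(c2ccc(Cl)cc2)C(c2ccc(Cl)cc2)N1C(=O)N1CCN(CCCCC(=O)NO)CC1` follows from compound 1 through one change (hydroxycarbamoyl in place of (hydroxycarbamoyl)methyl on a saturated chain carbon, four bonds along the chain from an amine nitrogen in a ring) that also reads as 4-(hydroxycarbamoyl)butyl to 3-(hydroxycarbamoyl)propyl. Among the measured compounds shown here, the only measured step (a 2.0-fold higher number from compound 2 to compound 3 (0.30 log units; within the scatter)) concerns a different exchange, so it bears on this change only indirectly. No shift beyond the scatter is expected in this assay and the expected step is small (a 1.1-fold higher number from compound 1 to compound 4 (0.05 log units; within the scatter)). For compound 4 the estimated value is 4500 nM with an expected range from 2000 nM to 10000 nM in repeat measurements.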

Compound 4, half-maximal inhibitory concentration: 5210 nM
Compound 4: the middle estimate sits 1.2-fold (0.06 log units) below what was measured; measured number inside the range.
By their numbers in this assay, from the lowest: compounds 1, 2, 4 and 3 (each within the scatter of the next, the first and the last beyond it).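

Among the compounds shown here, the exchange of 4-(hydroxycarbamoyl)butyl for 3-(hydroxycarbamoyl)propyl is the only step read directly on this chain, and in this assay it comes to a 1.3-fold higher number from compound 1 to compound 4 (0.11 log units; within the scatter). This shortening of the chain therefore leaves no shift that can be told from the scatter. Nothing measured here accounts for this result. Still open, on these data alone, is whether a longer chain or the shorter 2-(hydroxycarbamoyl)ethyl would stay within the scatter of compound 1. Also open, as far as these compounds go, is how a (2-aminophenyl)carbamoyl end group would read on this chain.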